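Selenium for Sulfur on the Shared Core of Compound 3

The source may report more compounds than this note shows. Statements on the series, on what has been measured and on what is new or still open speak of the compounds shown alone.

Compound 1, `COc1ccc(CNc2nc([SeH])nc3ccccc23)cc1`, in a functional assay on CCRF-CEM cells (Homo sapiens) for cytotoxicity, read by MTT assay, with a stated time of 72 h (a lower number here means a stronger inhibitor of growth, a higher number a weaker inhibitor of growth), gives > 100000 nM, which is a limit of the assay. Compound 2, `CSc1ccc(CNc2nc([SeH])nc3ccccc23)cc1`, in this assay gives > 100000 nM, again a limit. Compound 3, `Sc1nc(NCc2ccccc2)c2ccccc2n1`, in this assay gives > 100000 nM, also a limit.

Compound 3 therefore stands only at a limit, and so do the other two measured compounds: the limit of > 100000 nM in this assay, at which 3 of the 3 values shown sit. Among the compounds with values here, the one measured step, a step that the two limits leave unreadable from compound 1 to compound 2, is unreadable, since both ends of it are limits. The change to compound 4, `[SeH]c1nc(NCc2ccccc2)c2ccccc2n1`, is one selenium atom in place of one sulfur atom, on an aromatic carbon. Within the data shown here, no measured step touches an exchange of this kind, and the step from compound 1 to compound 2 offers no readable size to lean on. With every shown value at the limit and no step of measurable size, the expectation for compound 4 rests on compound 3 sitting at > 100000 nM, and the step that the limit leaves unreadable from compound 3 to compound 4 is estimated to be none beyond the scatter. Compound 4 is thus expected to give about 150000 nM, between 50000 nM and 500000 nM, most likely again reported only as a limit.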

Compound 4, concentration for total growth inhibition: > 100000 nM
Compound 4 was reported as a limit (the forecaster's own chance of this, stated with the estimate: 80%); the middle value is on the limit's open side.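

Compound 4 joins compound 1, compound 2 and compound 3 at a limit, so no step among these compounds can be read, including the exchange of sulfur for selenium: the limit of > 100000 nM in this assay, at which 4 of the 4 values shown sit.

The compounds shown leave open whether any of these single changes alters growth inhibition in this assay.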